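The source may hold more compounds than are shown below. What is called first, only, known or untested is meant among the compounds shown, and "the series" means these compounds.

Within the data shown here, compound 2, `O=C(Nc1ccc(Oc2ccnc3[nH]ccc23)c(F)c1)c1nn(-c2ccc(Br)cc2)ccc1=O`, is the only compound of this set to give a number in a functional assay on MCF7 cells (Homo sapiens) for cytotoxicity, read by MTT assay, with a stated time of 72 h (a lower number here means a stronger inhibitor, a higher number a weaker inhibitor), where compound 2 gives 11600 nM. Compound 1, `O=C(Nc1ccc(Oc2ccnc3[nH]ccc23)c(F)c1)c1nn(-c2ccc(Cl)cc2)ccc1=O`, is recorded only at a limit of this assay, for compound 1 stands at > 60000 nM. Among the measured compounds shown here, the one measured step, an at least 5.1-fold lower number from compound 1 to compound 2 (0.71 log units; beyond the scatter), rests on the limit of > 60000 nM in this assay, at which 1 of the 2 values shown sits, and concerns a change on the halogen-bearing ring. Compound 3, `Cn1ccc2c(Oc3ccc(NC(=O)c4nn(-c5ccc(Br)cc5)ccc4=O)cc3F)ccnc21`, differs from compound 2 elsewhere: methyl in place of hydrogen on an aromatic nitrogen. The measured step therefore does not bear directly on this change, and nothing in the set shows what substitution on that aromatic nitrogen does to cytotoxicity. With no guide, the expectation for compound 3 is a step of a 1.7-fold higher number from compound 2 to compound 3 (0.24 log units; within the scatter), likely no larger than the scatter, with a weakening slightly more probable than a gain. Compound 3 is accordingly estimated at 20000 nM, expected within the range 6000 nM to 60000 nM.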

Compound 3, half-maximal inhibitory concentration: 33600 nM
Beside the measured number, compound 3's estimate is 1.7-fold (0.23 log units) below it; low and high end bracket the measured number.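

In this assay, methyl in place of hydrogen on an aromatic nitrogen gives a 2.9-fold higher number from compound 2 to compound 3 (0.46 log units; beyond the scatter), a modest weakening. The earlier compounds shown here said nothing about this position, and this pair now shows that the position is not indifferent to the change, with the hydrogen-bearing compound 2 the stronger of the two. Unlike the step on the halogen-bearing ring, this step joins two actual numbers, and the only limit in the set belongs to compound 1: the limit of > 60000 nM in this assay, at which 1 of the 3 values shown sits.

One pair cannot show whether the weakening comes from losing the hydrogen or from adding the methyl, or whether it would recur with chloro in place of bromo. Also open, on these data alone, is how this nitrogen would respond to an ethyl group or to a longer chain ending in an amine or a carboxylic acid.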